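The source may hold more compounds than are shown below. What is called first, only, known or untested is meant among the compounds shown, and "the series" means these compounds.

In a functional assay on the whole organism (strain C57B/6) with Mus musculus as the target, in the maximal electroshock model (on this read-out lower numbers stand for an effect already at smaller amounts and higher numbers for an effect only at larger amounts of compound), compound 3, `CCCCCCOc1ccc(-n2cnnc2-c2ccc(OC)cc2)cc1`, gives 15.8 mg/kg. Among the compounds with values here, of the two numbers known here it is the higher one, and its nearest neighbour is compound 2, `CCCCCCOc1ccc(-n2cnnc2-c2ccc(C)cc2)cc1`, which gives 11.4 mg/kg; the gap is a 1.4-fold higher number from compound 2 to compound 3 (0.14 log units; within the scatter). Compound 1, `CCCCCCCCCc1nncn1-c1ccc(OCCCCCC)cc1`, yields no number at all in this assay but only a limit, > 40 mg/kg. Compared with that limit the steps of an at least 3.5-fold lower number from compound 1 to compound 2 (0.54 log units; beyond the scatter) and an at least 2.5-fold lower number from compound 1 to compound 3 (0.40 log units; beyond the scatter) both show that an aromatic ring on the shared core in place of a long chain lowers the number.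

Compound 4, `CCCCCCOc1ccc(-n2cnnc2Cc2ccccc2)cc1`, differs from compound 3 by a single change: benzyl in place of 4-methoxyphenyl on an aromatic carbon. Within the data shown here, no measured step matches this exactly. The step of a 1.4-fold higher number from compound 2 to compound 3 (0.14 log units; within the scatter) shows that exchanging the small group on the attached ring barely matters, while the two steps from compound 1 show that the presence of a directly attached aromatic ring matters. A benzyl keeps the ring but inserts a carbon link, so a small rise in the number is expected, on the order of a 1.4-fold higher number from compound 3 to compound 4 (0.14 log units; within the scatter). Compound 4 is therefore estimated at 22 mg/kg, with a likely range from 9 mg/kg to 50 mg/kg.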

Compound 4, dose for half-maximal effect: 19 mg/kg
For compound 4 the middle estimate is 1.2-fold (0.06 log units) above the measured one; low and high end bracket the measured number.
By their numbers in this assay, from the lowest: compounds 2, 3 and 4 (each within the scatter of the next). At a limit, above all of these: compound 1.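

In this assay, the aromatic ring at this position need not sit directly on the shared core: benzyl in place of 4-methoxyphenyl gives a 1.2-fold higher number from compound 3 to compound 4 (0.08 log units; within the scatter) and benzyl in place of 4-methylphenyl gives a 1.7-fold higher number from compound 2 to compound 4 (0.22 log units; within the scatter), so the inserted carbon link leaves compound 4 within the scatter of both. The first of these steps also removes the hydrogen-bond acceptor of 4-methoxyphenyl, and the number stays within the scatter. The comparison with the long chain now extends to a ring held on a carbon link, with an at least 2.1-fold lower number from compound 1 to compound 4 (0.32 log units; beyond the scatter) as phenyl replaces octyl on the same first chain carbon, though compound 1 supplies only a limit to this step: the limit of > 40 mg/kg in this assay, at which 1 of the 4 values shown sits.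

The compounds shown leave open whether a longer link, such as the two-carbon link of phenethyl, would still fall in this range of numbers, and where a short chain such as ethyl or butyl would fall between benzyl and nonyl. They also leave open what a ring carrying an amine or a carboxylic acid would do at this position.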